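Iodo for Isopropyl: Expected Tolerance of Compound 4

This account rests on a few compounds, and the source may have more. Where it says the series, first, only, none or still open, it means among the compounds named here.

Three compounds have so far been examined in an ADME assay on MT4 cells (Homo sapiens) for cytotoxicity, read by MTT assay; a higher number here means that more compound is tolerated, a lower number that less compound is tolerated. Compound 1 `Cc1ccccc1NC(=S)OCCc1ccccn1` gives only a limit in this assay, > 100000 nM, and not a number. Compound 2 `S=C(Nc1cccc(Cl)c1)OCCc1ccccn1` gives 47000 nM. Compound 3 `CC(C)c1ccc(NC(=S)OCCc2ccccn2)cc1` gives 45000 nM, the lowest of the two numbers on record, though its nearest neighbour, compound 2, sits within the usual scatter of it, so no order between the two can be claimed. No pair among these three compounds differs in only one place, so no measured step is available.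

Compound 4 `S=C(Nc1ccc(I)cc1)OCCc1ccccn1` has not yet been measured. It differs from compound 3 by iodo in place of isopropyl on an aromatic carbon. With no measured step to draw on, the step in this assay is expected to stay within the scatter, with no direction that can be argued from the numbers shown. Compound 4 is therefore estimated at 50000 nM, with a range from 20000 nM to 120000 nM, which means an expected step of a 1.1-fold higher number from compound 3 to compound 4 (0.05 log units; within the scatter).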

Compound 4, half-maximal cytotoxic concentration: 34000 nM
The estimate for compound 4 lay 1.5-fold (0.17 log units) above the measured number; the measured number falls inside the stated range.
By their numbers in this assay, from the lowest: compounds 4, 3 and 2 (each within the scatter of the next). At a limit, above all of these: compound 1.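

In this assay, among the compounds shown here, the exchange of isopropyl for iodo on an aromatic carbon, para to a large group, gives the first measured step: a 1.3-fold lower number from compound 3 to compound 4 (0.12 log units; within the scatter). At this position, then, the exchange of these two groups does not carry the number beyond the scatter, and no direction can be claimed for it. Compound 3 and compound 4 both give numbers and not a limit, so this step can be read: the limit of > 100000 nM in this assay, at which 1 of the 4 values shown sits.

From the compounds shown here alone, what an amine or a carboxylic acid at this position would do, and whether any group there would move the number beyond the scatter, stays open. For the compounds shown here, compound 1 gives a limit and not a number, and no step in one place links it to the other compounds, so what sets it apart also stays open.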